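A hydroxy group added to an inactive methoxy analogue

The compounds below may be only part of what the source reports. "The series", "measured", "known", "first", "only" and "open" are said of these compounds alone.

Measured in a functional assay on HL-60 cells (Homo sapiens) for inhibition, read by MTT assay, with a stated time of 72 h; a lower number here means a stronger inhibitor, a higher number a weaker inhibitor:
Compound 1 `Cc1nc(-c2ccccc2)c(C(=O)N2CCN(c3cccc(Cl)c3)CC2)o1` gives 39.2 nM
Compound 2 `Cc1nc(-c2cccc(F)c2)c(C(=O)N2CCN(c3cccc(Cl)c3)CC2)o1` gives 33.7 nM
Compound 3 `COc1cccc(-c2nc(C)oc2C(=O)N2CCN(c3cccc(Cl)c3)CC2)c1` gives "not active" (no number reported)

Compound 3 has no number in this assay: its result stands as "not active" (no number reported), so it cannot be placed on the scale beside the two compounds that gave values. The next analogue, compound 4 `COc1cc(-c2nc(C)oc2C(=O)N2CCN(c3cccc(Cl)c3)CC2)ccc1O`, turns its 3-methoxyphenyl into 4-hydroxy-3-methoxyphenyl, with hydroxy in place of hydrogen on an aromatic carbon.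

Among the measured compounds shown here, only one measured step exists, a 1.2-fold lower number from compound 1 to compound 2 (0.07 log units; within the scatter). It lies within the scatter, but it concerns fluoro rather than hydroxy and starts from a different compound, so it offers only weak guidance. With no number for compound 3, no step size can be set for this change, and even its direction can only be expected loosely. A measurable value for compound 4 is plausible, though probably a weaker one than those of compound 1 and compound 2, and another result without a number would be no surprise. For compound 4 the expected value is 600 nM, with an estimated range from 40 nM to 10000 nM.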

Compound 4, half-maximal inhibitory concentration: 85.9 nM
Estimate against measurement, compound 4: 7.0-fold (0.84 log units) above; measured number inside the range.
By their numbers in this assay, from the lowest: compounds 2 and 1 (each within the scatter of the next); then compound 4.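

In this assay compound 3 stands as "not active" (no number reported), while compound 4, with hydroxy in place of hydrogen ortho to the methoxy group, gives 85.9 nM. A ring carrying a methoxy group can therefore give a measurable value when this hydroxy group is also present, although no size can be read for the change. The 4-hydroxy-3-methoxyphenyl group still falls short of the two simpler rings, with a 2.5-fold higher number from compound 2 to compound 4 (0.41 log units; beyond the scatter) and a 2.2-fold higher number from compound 1 to compound 4 (0.34 log units; beyond the scatter), and no available evidence accounts for this result.

The compounds shown leave open whether a hydroxy group on the ring without the methoxy group would give a value close to that of compound 1. They also leave open whether an amine or a carboxylic acid at the same place would give a measurable value as hydroxy does.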